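The source may report more compounds than this note shows. Statements on the series, on what has been measured and on what is new or still open speak of the compounds shown alone.

Compound 1 `CC(O)(CS(=O)(=O)c1ccc(S(F)(F)(F)(F)F)cc1)C(=O)Nc1ccc(S(F)(F)(F)(F)F)cc1` at 15700 nM
Compound 2 `CC(O)(CS(=O)(=O)c1ccc(F)cc1)C(=O)Nc1ccc(S(F)(F)(F)(F)F)cc1` at 34200 nM

In a functional assay on VCaP cells (Homo sapiens) for antiproliferative activity, read by propidium iodide staining, with a stated time of 96 h (a higher number here means a weaker inhibitor, a lower number a stronger inhibitor), compound 2 has the higher of the two numbers (34200 nM), which makes it the weaker inhibitor so far. Compound 3 `CC(O)(CS(=O)(=O)c1ccc(C(F)(F)F)cc1)C(=O)Nc1ccc(S(F)(F)(F)(F)F)cc1` carries trifluoromethyl in place of fluoro on an aromatic carbon. Among the compounds with values here, the only measured step that bears on this change swapped the group at that same place (a 2.2-fold higher number from compound 1 to compound 2 (0.34 log units; beyond the scatter)). That step was modest, and the larger group gave the lower number, so only a small fall is expected, possibly within the scatter. The expected change in this assay is small (a 1.4-fold lower number from compound 2 to compound 3 (0.15 log units; within the scatter)). Compound 3 is estimated at 24000 nM (expected range 12000 nM to 45000 nM).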

Compound 3, half-maximal inhibitory concentration: 27700 nM
Beside the measured number, compound 3's estimate is 1.2-fold (0.06 log units) below it; the measured number falls inside the stated range.
By their numbers in this assay, from the lowest: compounds 1, 3 and 2 (each within the scatter of the next, the first and the last beyond it).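

In this assay, trifluoromethyl at this place on the ring cannot be told apart from fluoro, with (a 1.2-fold lower number from compound 2 to compound 3 (0.09 log units; within the scatter)), nor from the larger sulfur-bearing group, with (a 1.8-fold higher number from compound 1 to compound 3 (0.25 log units; within the scatter)). The only gap beyond the scatter among these three groups therefore lies between the two end members, and the middle one adds no clear step of its own. Nothing available explains these numbers. As far as these compounds go, it remains open whether an amine, a carboxylic acid or a longer chain at this place would shift the number beyond the scatter from that of compound 3.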